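Methyl on an aromatic carbon of compound 3

The source may report more compounds than this note shows. Statements on the series, on what has been measured and on what is new or still open speak of the compounds shown alone.

Compound 3 `O=c1c([C@@H]2C[C@H](c3ccccc3)ON2c2ccccc2)coc2ccccc12` gives > 60000 nM in a functional assay on THP-1 cells (Homo sapiens) for inhibition, read by sulforhodamine B assay, with a stated time of 48 h (on this read-out lower numbers stand for stronger inhibition and higher numbers for weaker inhibition), and that value is a limit, not a number. Compound 1 `COC(=O)[C@H]1C[C@@H](c2coc3ccccc3c2=O)N(c2ccccc2)O1` gives > 60000 nM in this assay and that too is a limit. Among the compounds with values here, compound 2 `O=c1c([C@@H]2C[C@H](c3ccccc3)ON2c2ccccc2)coc2ccc(F)cc12` gives 54700 nM in this assay as the only number so far. The series thus shows the limit of > 60000 nM in this assay, at which 2 of the 3 values shown sit, and a single number beside it.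

Compound 4 `Cc1ccc2occ([C@@H]3C[C@H](c4ccccc4)ON3c3ccccc3)c(=O)c2c1` differs from compound 3 by methyl in place of hydrogen on an aromatic carbon and in nothing else.

Of the measured steps, a step that the two limits leave unreadable from compound 1 to compound 3 concerns phenyl in place of methoxycarbonyl on a saturated ring carbon and does not bear on this change. The closer case is an at least 1.0-fold higher number from compound 2 to compound 3 (0.04 log units; that floor lies within the scatter) for hydrogen in place of fluoro on an aromatic carbon. Within the data shown here, with that step from compound 2 as the only guide, no step beyond the scatter is expected in this assay for compound 4 and no direction is expected either. The estimated step is a number no higher from compound 3 to compound 4 (the limit leaves the size open) and it is expected to stay small. For compound 4 the estimated value is 60000 nM with an expected range from 30000 nM to 120000 nM and a fair chance of only a limit.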

Compound 4, half-maximal inhibitory concentration: > 60000 nM
Compound 4: only a limit was reported; the forecaster's own chance of this, stated with the estimate: 65%; the middle value lies on the limit itself.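

In this assay compound 4 gives > 60000 nM, and that value is a limit, so the step from hydrogen to methyl on this aromatic carbon cannot be read, as neither can any other step between two limits. Within the data shown here, the one readable comparison at this position is methyl in place of fluoro, which gives an at least 1.0-fold higher number from compound 2 to compound 4 (0.04 log units; that floor lies within the scatter); this is only a floor, so the size of the step remains open, and the two groups are not separated on the evidence here. With methyl added, the picture for this carbon is one of values gathering at the ceiling of the read-out rather than of any readable trend: the limit of > 60000 nM in this assay, at which 3 of the 4 values shown sit.

The compounds shown leave open whether any group on this carbon can bring a value clearly below that limit, since only hydrogen, fluoro and methyl appear there, and an amine, a carboxylic acid or a longer chain at this position would test that. Also open, going by these compounds, is whether the other carbons of this aromatic ring respond differently, as all the substituents shown sit on the one carbon.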